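From compound 2 to compound 3: one swapped group

The compounds below may be only part of what the source reports. "The series", "measured", "known", "first", "only" and "open" are said of these compounds alone.

Solubility is the amount of a compound that stays dissolved, and only two readings exist for this series so far. In a physicochemical assay for solubility, read by HPLC, in phosphate buffer, with a stated time of 20 min, at pH 9.0 (on this read-out higher numbers stand for higher solubility and lower numbers for lower solubility), compound 1 `CCC(CC)O[C@@H]1C=C(C(=O)O)C[C@H](NC(C)=N)[C@H]1NC(C)=O` gives > 50000000 nM, which is a limit of the assay and not a number. Going by the values given here, compound 2 `CCOC(=O)C1=C[C@@H](OC(CC)CC)[C@H](NC(C)=O)[C@@H](N/C(C)=N/O)C1`, at 23000000 nM, holds the only actual number. Compound 3 `CCOC(=O)C1=C[C@@H](OC(CC)CC)[C@H](NC(C)=O)[C@@H](N/C(N)=N\O)C1` keeps the core of compound 2 and changes one group on an amine nitrogen (a group of 4 heavy atoms (1 carbon, 2 nitrogen, 1 oxygen; no ring) in place of a group of 4 heavy atoms (2 carbon, 1 nitrogen, 1 oxygen; no ring), on an amine nitrogen). Among the compounds with values here, no measured pair shows this swap, so the value of compound 2 at 23000000 nM is the only starting point, and the two groups are of equal size in heavy atoms. The estimated step of a 1.3-fold lower number from compound 2 to compound 3 (0.11 log units; within the scatter) is expected to stay within the usual scatter of repeated measurements in this assay. For compound 3 the expected value is 18000000 nM, with a likely range from 6000000 nM to 50000000 nM.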

Compound 3, solubility: > 50000000 nM
Compound 3: only a limit was reported; the forecaster's own chance of this, stated with the estimate: 12%; middle value at least 2.7-fold (0.44 log units) away from the limit.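

In this assay, going by these compounds alone, swapping the group on the amine nitrogen gives an at least 2.1-fold higher number from compound 2 to compound 3 (0.33 log units; beyond the scatter), the first step that can be read at all. Compound 3 gives > 50000000 nM, which is a limit of the assay and not a number, so the step has a known lower bound but no known upper one. The true size of this change therefore stays hidden, and the same ceiling affects most of the series: the limit of > 50000000 nM in this assay, at which 2 of the 3 values shown sit.

As far as these compounds go, how far compound 3 lies past that limit remains open, as does whether this swap would give a similar step on a different core. Also open, from the compounds shown here alone, is whether a plain amine or a longer chain on that nitrogen would give a reading inside the range of the assay.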